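From 3-nitrophenyl to 4-nitrophenyl: one small swap

The source may hold more compounds than are shown below. What is called first, only, known or untested is meant among the compounds shown, and "the series" means these compounds.

In a functional assay on MCF7 cells (Homo sapiens) for cytotoxicity, read by MTT assay, with a stated time of 96 h (on this read-out lower numbers stand for stronger inhibition and higher numbers for weaker inhibition), compound 1 `COc1cc(C(=O)c2cn(-c3ccccc3)cc2-c2ccc([N+](=O)[O-])cc2)cc(OC)c1OC` gives 590 nM and compound 2 `COc1cc(C(=O)c2cn(-c3ccc(C)cc3)cc2-c2cccc([N+](=O)[O-])c2)cc(OC)c1OC` gives 210 nM as the lower of the two numbers, a gap beyond the usual scatter. Compound 3 `COc1cc(C(=O)c2cn(-c3ccc(C)cc3)cc2-c2ccc([N+](=O)[O-])cc2)cc(OC)c1OC` matches compound 2 except for one group: 4-nitrophenyl replaces 3-nitrophenyl on an aromatic carbon 4-nitrophenyl in place of 3-nitrophenyl on an aromatic carbon while the rest stays the same. Among the measured compounds shown here, no measured pair shows this swap alone. Compound 1 also carries 4-nitrophenyl, but it differs from compound 2 elsewhere too, so the number for compound 1, 590 nM, is only a rough guide that points toward a higher number. In this assay the expected change is a 2.1-fold higher number from compound 2 to compound 3 (0.33 log units; beyond the scatter) as a modest move toward weaker inhibition. The estimate for compound 3 is 450 nM with 170 nM to 1100 nM as the expected range.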

Compound 3, half-maximal inhibitory concentration: 200 nM
Estimate against measurement, compound 3: 2.3-fold (0.35 log units) above; the range from low to high includes it.
By their numbers in this assay, from the lowest: compounds 3 and 2 (each within the scatter of the next); then compound 1.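

In this assay, putting 4-nitrophenyl in place of 3-nitrophenyl on this aromatic carbon yields a 1.1-fold lower number from compound 2 to compound 3 (0.02 log units; within the scatter), so the two nitrophenyl groups cannot be told apart at this position. With 4-nitrophenyl held fixed, methyl in place of hydrogen on an aromatic carbon yields a 3.0-fold lower number from compound 1 to compound 3 (0.47 log units; beyond the scatter), so the higher number of compound 1 goes with the missing methyl and not with 4-nitrophenyl. Nothing measured here says why either step came out as it did.

Still open, as far as these compounds go, is whether an amine or a carboxylic acid in place of the nitro group on this phenyl ring would leave the number unchanged. Also open, from the compounds shown here alone, is whether an ethyl group in place of the methyl would hold the lower number seen for compound 3.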